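Changing the side arm on the shared core of compound 3

This account rests on a few compounds, and the source may have more. Where it says the series, first, only, none or still open, it means among the compounds named here.

Three measured compounds share one core and differ only in the group carried on an aromatic carbon of a five-membered aromatic ring with one nitrogen. Compound 1 `CC(=O)OC[C@H]1O[C@@H](n2cc(Cn3cc(C(C)=O)c4ccccc43)nn2)[C@H](OC(C)=O)[C@@H](OC(C)=O)[C@@H]1OC(C)=O` carries an acetyl group there; in a functional assay on DU-145 cells (Homo sapiens) for cytotoxicity, read by sulforhodamine B assay, with a stated time of 48 h (on this read-out higher numbers stand for weaker inhibition and lower numbers for stronger inhibition), compound 1 gives 75200 nM. Compound 2 `CC(=O)OC[C@H]1O[C@@H](n2cc(Cn3cc([N+](=O)[O-])c4ccccc43)nn2)[C@H](OC(C)=O)[C@@H](OC(C)=O)[C@@H]1OC(C)=O` carries a nitro group instead, and in this assay compound 2 gives 60900 nM, which amounts to a 1.2-fold lower number from compound 1 to compound 2 (0.09 log units; within the scatter). Compound 3 `CC(=O)OC[C@H]1O[C@@H](n2cc(Cn3cc(/C=C/C(=O)c4cccnc4)c4ccccc43)nn2)[C@H](OC(C)=O)[C@@H](OC(C)=O)[C@@H]1OC(C)=O` carries a 2-((pyridin-3-yl)carbonyl)ethenyl group, and in this assay compound 3 gives 29000 nM, the lowest number of the three: a 2.6-fold lower number from compound 1 to compound 3 (0.41 log units; beyond the scatter) and a 2.1-fold lower number from compound 2 to compound 3 (0.32 log units; beyond the scatter).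

Compound 4 `CC(=O)OC[C@H]1O[C@@H](n2cc(Cn3cc(/C=C4/C(=O)Nc5ccccc54)c4ccccc43)nn2)[C@H](OC(C)=O)[C@@H](OC(C)=O)[C@@H]1OC(C)=O` has not yet been measured. It differs from compound 3 by a group of 11 heavy atoms (9 carbon, 1 nitrogen, 1 oxygen; one five-membered non-aromatic ring with 1 hetero atom, one six-membered aromatic ring of carbon only) in place of a group of 10 heavy atoms (8 carbon, 1 nitrogen, 1 oxygen; one six-membered aromatic ring with 1 hetero atom), on an aromatic carbon. Among the measured compounds shown here, none of the measured steps exchanges one large group for another of similar size; the two steps that reach compound 3 only show that a longer chain in place of a small group brought a modest gain. For the measured compounds named here, with no step of the same kind to lean on, the expectation for compound 4 is a number close to that of compound 3, so the step of a 1.0-fold higher number from compound 3 to compound 4 (0.01 log units; within the scatter) is expected to stay within the scatter. The estimate for compound 4 in this assay is 30000 nM, in a range from 10000 nM to 90000 nM.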

Compound 4, half-maximal inhibitory concentration: > 200000 nM
Compound 4: no number, only a limit; the forecaster's own chance of this, stated with the estimate: 15%; middle value at least 6.6-fold (0.82 log units) away from the limit.
By their numbers in this assay, from the lowest: compound 3; then compounds 2 and 1 (each within the scatter of the next). At a limit, above all of these: compound 4.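

Compound 4 has no number in this assay, only a limit, and it is the one compound here that stands at it: the limit of > 200000 nM in this assay, at which 1 of the 4 values shown sits.

Even so, the limit is enough to show that this aromatic carbon does not tolerate every large group, since exchanging the 2-((pyridin-3-yl)carbonyl)ethenyl group for a group of similar size gives an at least 6.8-fold higher number from compound 3 to compound 4 (0.83 log units; beyond the scatter). The earlier compounds showed only a modest gain from a large group, whereas the new group also falls behind both small groups, with an at least 3.2-fold higher number from compound 2 to compound 4 (0.51 log units; beyond the scatter) and an at least 2.6-fold higher number from compound 1 to compound 4 (0.42 log units; beyond the scatter), so size alone does not set the outcome among these four compounds.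

Which part of the entering group matters stays open: it differs from the leaving group in its rings and in its counts of hydrogen-bond donors and acceptors, and these compounds do not separate those differences. Also open, as far as these compounds go, are the true size of the loss for compound 4 and how a simple amine or a carboxylic acid on this aromatic carbon would compare.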